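The compounds below may be only part of what the source reports. "The series", "measured", "known", "first", "only" and "open" are said of these compounds alone.

Compound 1 `CCOC(=O)C1=Cc2ccccc2OC1(OCc1cc(-c2ccc3ccccc3c2)no1)C(F)(F)F`: 65400 nM
Compound 2 `COc1ccc(-c2cc(COC3(C(F)(F)F)Oc4ccccc4C=C3C(=O)O)on2)cc1`: 35200 nM
Compound 3 `O=C(O)C1=Cc2ccccc2OC1(OCc1cc(-c2ccc3ccccc3c2)no1)C(F)(F)F`: a limit, > 150000 nM

In a functional assay on MCF7 cells (Homo sapiens) for inhibition, read by MTT assay, with a stated time of 24 h (on this read-out higher numbers stand for weaker inhibition and lower numbers for stronger inhibition), compound 1 has the higher of the two numbers shown, yet compound 2 sits within the scatter of it. For compound 3 the assay reports only a limit rather than a number. The unmeasured compound 4 `CCOC(=O)C1=Cc2ccccc2OC1(OCc1cc(-c2ccc(F)cc2)no1)C(F)(F)F` differs from compound 1 by 4-fluorophenyl in place of naphthalen-2-yl on an aromatic carbon. Among the measured compounds shown here, one measured step bears on this: an at least 4.2-fold higher number from compound 2 to compound 3 (0.62 log units; beyond the scatter), which runs the opposite way, from a small aryl group to naphthalen-2-yl. The step of an at least 2.2-fold higher number from compound 1 to compound 3 (0.36 log units; beyond the scatter) concerns the ester, not the aryl group, and does not bear. Going back to a small aryl group, a modest drop is therefore expected, a 3.0-fold lower number from compound 1 to compound 4 (0.47 log units; beyond the scatter). Compound 4 is estimated at 22000 nM, between 8000 nM and 60000 nM.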

Compound 4, half-maximal inhibitory concentration: 48200 nM
Compound 4: middle estimate off by 2.2-fold (0.34 log units), on the low side; the measured number falls inside the stated range.
By their numbers in this assay, from the lowest: compounds 2, 4 and 1 (each within the scatter of the next). At a limit, above all of these: compound 3.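

In this assay, among ethyl esters, the change at this position gives a 1.4-fold lower number from compound 1 to compound 4 (0.13 log units; within the scatter), so one aromatic ring with a fluorine serves here as well as the two fused rings of naphthalen-2-yl, as far as this read-out can tell. The earlier aryl comparison was among carboxylic acids and rested on a limit, whereas this one rests on two numbers. Nothing shown here explains the result.

Still open, on these data alone, is whether a plain phenyl, a longer alkyl chain or an amine on this aromatic carbon would shift the number beyond the scatter. Also open, as far as these compounds go, is how 4-methoxyphenyl behaves on the ethyl ester.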